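Benzyl in place of 3-hydroxyphenyl: expectation for compound 4

The compounds below may be only part of what the source reports. "The series", "measured", "known", "first", "only" and "open" are said of these compounds alone.

Compound 1 `CCOC(=O)C1=C(C)N/C(=C/c2cc(C)n(-c3ccc(OC)cc3)c2C)C1=O` gives 140000 nM in an ADME assay on L6 cells (Rattus norvegicus) for cytotoxicity, read by resazurin assay, with a stated time of 72 h; on this read-out lower numbers stand for an effect already at smaller amounts and higher numbers for an effect only at larger amounts of compound.
Compound 2 `CCOC(=O)C1=C(C)N/C(=C/c2cc(C)n(-c3cc(OC)c(OC)c(OO)c3)c2C)C1=O` gives 46000 nM in this assay.
Compound 3 `CCOC(=O)C1=C(C)N/C(=C/c2cc(C)n(-c3cccc(O)c3)c2C)C1=O` gives 69000 nM in this assay.

Compound 3 stands second highest of the three numbers. Its nearest neighbour is compound 2, whose number is within the scatter of that of compound 3, so no order between the two can be read. The one step shown, a 2.0-fold lower number from compound 1 to compound 3 (0.31 log units; beyond the scatter), is modest and just beyond the scatter.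

Compound 4 `CCOC(=O)C1=C(C)N/C(=C/c2cc(C)n(Cc3ccccc3)c2C)C1=O` is not yet measured in this assay. The change from compound 3 is benzyl in place of 3-hydroxyphenyl on an aromatic nitrogen. Within the data shown here, the only measured step at the same place, a 2.0-fold lower number from compound 1 to compound 3 (0.31 log units; beyond the scatter), exchanged one substituted phenyl for another and moved the number only modestly; no measured step exchanges a phenyl for a benzyl, so the direction of the present change is unknown. Given that all three measured numbers lie within a narrow band, the step of a 1.0-fold higher number from compound 3 to compound 4 (0.01 log units; within the scatter) is expected to be small, most likely within the scatter. Compound 4 is therefore estimated at 70000 nM, with a range from 25000 nM to 200000 nM in this assay.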

Compound 4, half-maximal effective concentration: 50000 nM
The estimate for compound 4 lay 1.4-fold (0.15 log units) above the measured number, within the range that was stated.
By their numbers in this assay, from the lowest: compounds 2, 4 and 3 (each within the scatter of the next); then compound 1.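

In this assay, the exchange on the aromatic nitrogen now reaches beyond one substituted phenyl for another: benzyl, which has neither the hydrogen-bond donor nor the hydrogen-bond acceptor of 3-hydroxyphenyl, gives a 1.4-fold lower number from compound 3 to compound 4 (0.14 log units; within the scatter), so this read-out does not separate the two groups. Among these compounds, measured against the 4-methoxyphenyl of compound 1, the same benzyl gives a 2.8-fold lower number from compound 1 to compound 4 (0.45 log units; beyond the scatter), which stands alongside a 2.0-fold lower number from compound 1 to compound 3 (0.31 log units; beyond the scatter) and leaves 4-methoxyphenyl as the one group of these three whose number is set apart from another's, though only by modest steps. Nothing available explains why 3-hydroxyphenyl and benzyl cannot be told apart here, or why 4-methoxyphenyl stands apart from them.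

Still open, going by these compounds, is whether a group of another kind on the aromatic nitrogen, such as a longer alkyl chain or an amine, would take the number in this assay well outside the band seen so far. Equally open is whether a carboxylic acid or a methoxy group on the ring of the benzyl would change the number at all, since only the unsubstituted benzyl is shown.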